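This account rests on a few compounds, and the source may have more. Where it says the series, first, only, none or still open, it means among the compounds named here.

Compound 1 `Cc1cc(/C=C/C#N)ccc1Nc1ccnc(Nc2ccc(C#N)cc2)n1` stands only at a limit in an ADME assay on MT4 cells (Homo sapiens) for cytotoxicity, with a stated time of 3 days; on this read-out higher numbers stand for lower toxicity in this test and lower numbers for higher toxicity in this test: compound 1 gives > 25000 nM, a limit of the test rather than a number. Compound 2 `N#C/C=C/c1ccc(Nc2ccnc(Nc3ccc(C#N)cc3)n2)cc1` also gives a limit in this assay, namely > 25000 nM. The one measured step, a step that the two limits leave unreadable from compound 1 to compound 2, is unreadable for that reason, as shown by the limit of > 25000 nM in this assay, at which 2 of the 2 values shown sit. Compound 3 `Cc1cc(/C=C/C#N)ccc1N(C)c1ccnc(Nc2ccc(C#N)cc2)n1` differs from compound 1 by methyl in place of hydrogen on a nitrogen on an aromatic ring. For the measured compounds named here, no measured step touches this nitrogen, so no size or direction can be read for it. Compound 3 is therefore expected to remain near the limit, at 25000 nM (range 8000 nM to 80000 nM), an expected step of a number no higher from compound 1 to compound 3 (the limit leaves the size open) within scatter.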

Compound 3, half-maximal cytotoxic concentration: 11600 nM
Estimate against measurement, compound 3: 2.2-fold (0.33 log units) above, and the stated range covers the measured number.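

In this assay, methyl in place of hydrogen on this nitrogen gives an at least 2.1-fold lower number from compound 1 to compound 3 (0.33 log units; beyond the scatter). For the compounds shown here, this is the first step in the set with a readable direction, and it shows that a single added carbon at this nitrogen can lower the number. Going by these compounds alone, compound 3 holds the only value here that is not a limit: the limit of > 25000 nM in this assay, at which 2 of the 3 values shown sit.

On these data alone, whether a longer chain such as ethyl on this nitrogen would lower the number further remains open. Also open, as far as these compounds go, is whether the same methyl would give a similar step on compound 2.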